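A few compounds are considered here, and "the series" means these few. Any claim that something is new, unique, unknown or untested is made for them only; others in the source may bear on it.

Measured so far:
compound 1 (`COc1ccc(Nc2nc(-n3ccnc3C)cs2)cc1`) – > 100000 nM
compound 2 (`COc1ccc(Nc2nc(-n3ccnc3)cs2)cc1`) – > 100000 nM
Not yet measured: compound 3 (`COc1ccc(Nc2nc(-n3cc(C)nc3C)cs2)cc1`)

In a functional assay on RKO cells (Homo sapiens) for cytotoxicity, read by resazurin assay, with a stated time of 72 h (a lower number here means a stronger inhibitor, a higher number a weaker inhibitor), compound 2 gives > 100000 nM as a limit of the assay, not a number. Compound 1 likewise gives > 100000 nM as a limit. The position of compound 2 therefore comes down to one shared mark, (the limit of > 100000 nM in this assay, at which 2 of the 2 values shown sit), and no number stands on either side of it.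

The change to compound 3 is 2,4-dimethyl-1H-imidazol-1-yl in place of 1H-imidazol-1-yl on an aromatic carbon. Among the measured compounds shown here, the only measured step that bears on it is a step that the two limits leave unreadable from compound 1 to compound 2 with hydrogen in place of methyl on an aromatic carbon, and it offers no size to carry over. Because of the limit of > 100000 nM in this assay, at which 2 of the 2 values shown sit, the expectation in this assay is no step beyond the scatter, in neither direction, and most likely another report of a limit alone. The estimated step is a number no higher from compound 2 to compound 3 (the limit leaves the size open) for this change. Compound 3 is expected at 100000 nM in an estimated range from 50000 nM to 200000 nM in this series.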

Compound 3, half-maximal inhibitory concentration: > 100000 nM
Compound 3 ended at the assay's limit; the forecaster's own chance of this, stated with the estimate: 85%; the middle value sits exactly at the limit.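

No new step can be read among compound 1, compound 2 and compound 3 in this assay, because all three results are limits and not numbers: the limit of > 100000 nM in this assay, at which 3 of the 3 values shown sit.

The compounds shown leave open how large the effect of the methyl groups on the 1H-imidazol-1-yl group is, and what change to the shared core would give a value inside the range of this assay.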